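The source may report more compounds than this note shows. Statements on the series, on what has been measured and on what is new or still open speak of the compounds shown alone.

In a functional assay (trachea) with Cavia porcellus as the target (a higher number here means that more compound is needed for the effect, a lower number that less compound is needed), compound 1 `CCCn1c(=O)n(CC)c(=O)c2[nH]cnc21` gives 1300 nM, compound 2 `CCCn1c(=O)n(CCC(N)=O)c(=O)c2[nH]cnc21` gives 13100 nM and compound 3 `CCCn1c(=O)n(CCC#N)c(=O)c2[nH]cnc21` gives 1700 nM. Compound 3 cannot be told apart from compound 1 within the scatter, while the number for compound 2 lies clearly higher, as the step of a 7.7-fold lower number from compound 2 to compound 3 (0.89 log units; beyond the scatter) shows. The next molecule is compound 4 `CCCn1c(=O)n(CCCO)c(=O)c2[nH]cnc21`, and the change is hydroxymethyl in place of cyano on a saturated chain carbon, two bonds along the chain from an aromatic nitrogen.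

The measured steps at that same carbon point two ways. Cyano in place of hydrogen gave a 1.3-fold higher number from compound 1 to compound 3 (0.12 log units; within the scatter), whereas carbamoyl in place of hydrogen gave a 10-fold higher number from compound 1 to compound 2 (1.00 log units; beyond the scatter). Hydroxymethyl has not been measured at this carbon, so either outcome remains open, and a middle course is the cautious guess. The expected step in this assay is modest and upward, a 2.1-fold higher number from compound 3 to compound 4 (0.31 log units; beyond the scatter). The estimate for compound 4 is 3500 nM, with an expected range of 1200 nM to 12000 nM.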

Compound 4, half-maximal effective concentration: 5100 nM
Compound 4: the middle estimate sits 1.5-fold (0.16 log units) below what was measured; the measured number falls inside the stated range.
By their numbers in this assay, from the lowest: compounds 1 and 3 (each within the scatter of the next); then compound 4; then compound 2.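

In this assay hydroxymethyl on this carbon takes a middle place, since the change from cyano gives a 3.0-fold higher number from compound 3 to compound 4 (0.48 log units; beyond the scatter) and the change from hydrogen gives a 3.9-fold higher number from compound 1 to compound 4 (0.59 log units; beyond the scatter) while the change from carbamoyl gives a 2.6-fold lower number from compound 2 to compound 4 (0.41 log units; beyond the scatter) in the opposite direction. Cyano and hydroxymethyl have the same count of heavy atoms, so that count alone does not set the number at this carbon. Nothing shown here explains what lies behind these differences.

The compounds shown leave open how an amine or a carboxylic acid on this carbon would compare with these groups. They also leave open whether a longer chain ending in a hydroxyl group would raise the number further or bring it back down.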